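Sulfonyl aryl exchange at high single-concentration inhibition

A few compounds are considered here, and "the series" means these few. Any claim that something is new, unique, unknown or untested is made for them only; others in the source may bear on it.

Three compounds of the series share one core and differ at the aryl on the sulfonyl sulfur and at the core substituents. In an assay on isolated protein for displacement of a labelled ligand from metabotropic glutamate receptor 5 (Homo sapiens), with a stated time of 60 min, tested at 1 uM (a higher number here means more inhibition at the concentration tested (going by the name of the read-out), a lower number less inhibition), compound 1 `Cc1ccc(S(=O)(=O)c2cnc3cc(Cl)ccc3c2N2CCC(C)CC2)cc1F` gives 85%; compound 2 `CC1CCN(c2c(S(=O)(=O)c3cccc(Cl)c3)cnc3ccc(Cl)cc23)CC1` gives 92% and compound 3 `COc1ccc2ncc(S(=O)(=O)c3ccc(C)cc3)c(N3CCC(C)CC3)c2c1` gives 90%. The three numbers lie within the usual scatter of one another, so compound 1 stands level with compound 2 and compound 3 on this read-out, and no steps between them are shown.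

Compound 4 `CC1CCN(c2c(S(=O)(=O)c3cc(F)cc(F)c3)cnc3cc(Cl)ccc23)CC1` is not yet measured. It differs from compound 1 by 3,5-difluorophenyl in place of 3-fluoro-4-methylphenyl on a sulfonyl sulfur. With all measured aryl variants giving similar inhibition, the step is expected to be none beyond the scatter, estimated as no change at the digits printed from compound 1 to compound 4 (within the scatter). Compound 4 is expected to give 85%, in the range 65% to 97%.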

Compound 4, a percentage reported as inhibition, at one concentration (the size of the read-out at that concentration, not a potency): 94%
Compound 4: the middle estimate sits 9 percentage points below what was measured, within the range that was stated.
By their numbers in this assay, from the lowest: compounds 1, 3, 2 and 4 (each within the scatter of the next).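

This is the only comparison shown that changes a single place: 3,5-difluorophenyl in place of 3-fluoro-4-methylphenyl on a sulfonyl sulfur gives a number 9 percentage points higher from compound 1 to compound 4 (within the scatter) in this assay. At this position, then, a second fluorine can stand in place of the methyl without inhibition moving beyond the scatter. Nothing available speaks to the origin of this result.

With every number high at one concentration, any real difference between these aryl groups remains unresolved. Also open, as far as these compounds go, is whether a phenyl carrying an amine or a carboxylic acid on the sulfonyl sulfur would keep this inhibition.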